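This account rests on a few compounds, and the source may have more. Where it says the series, first, only, none or still open, it means among the compounds named here.

Measured so far:
compound 1 `CO[C@@H]1[C@@H](OC)[C@H](c2ccccc2)O[C@@H]2CO[C@@H](c3ccccc3)O[C@@H]12` — "not determined" (no result reported)
compound 2 `CO[C@@H]1[C@@H](OC)[C@H](c2ccccc2)O[C@@H]2CO[C@@H](c3ccc4ccccc4c3)O[C@@H]12` — >= 16 ug/mL
compound 3 `CO[C@H]1[C@H]2O[C@H](c3ccccc3)OC[C@H]2O[C@@H](c2ccccc2)[C@@H]1OC` — > 400 ug/mL

Of the compounds shown here, three share the same core and have been tested in a functional assay on HEL cells (Homo sapiens) for cytotoxicity; a lower number here means that less compound is tolerated, a higher number that more compound is tolerated. Compound 1 has no result in this assay and is recorded as "not determined" (no result reported). For compound 2 this assay reports only a limit, >= 16 ug/mL. For compound 3 the result in this assay is likewise a limit, > 400 ug/mL, so compound 3 stands at a boundary rather than at a number (the limit of > 400 ug/mL in this assay, at which 1 of the 3 values shown sits), and the value of compound 2 is the other boundary (the limit of >= 16 ug/mL in this assay, at which 1 of the 3 values shown sits). Compound 1 and compound 3 are related through configuration alone (the fact that compounds 1 and 3 differ only in the configuration as drawn), but with no number for compound 1 nothing follows from that pair.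

The next compound is compound 4 `CO[C@H]1[C@@H]2O[C@H](c3ccccc3)OC[C@H]2O[C@@H](c2ccccc2)[C@H]1OC`. Against compound 3 the change is this: the two compounds have the same atoms and bonds and differ only in configuration as drawn: 2 of 6 stereo elements differ; a stereocentre at a saturated ring carbon is drawn S in compound 3 and R in compound 4; a stereocentre at a saturated ring carbon is drawn S in compound 3 and R in compound 4. Going by the values given here, no step between two measured compounds is available, so there is no measured handle on what such an inversion does in this assay; the expectation is a step of no more than the scatter, in no preferred direction. Compound 4 is therefore expected at 300 ug/mL, within 50 ug/mL to 400 ug/mL, and the expected step of an at least 1.3-fold lower number from compound 3 to compound 4 (0.12 log units; that floor lies within the scatter) is essentially none.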

Compound 4, minimum cytotoxic concentration: 400 ug/mL
For compound 4 the middle estimate is 1.3-fold (0.12 log units) below the measured one; the range from low to high includes it.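

Compound 4 gives the series its first plain number in this assay, 400 ug/mL. Compound 3 stands at > 400 ug/mL, which is a limit and not a number. The pair therefore gives a number no higher from compound 3 to compound 4 (the limit leaves the size open), so the size of this step cannot be read, and what it adds is a direction tied to one kind of change at two saturated ring carbons: the fact that compounds 3 and 4 differ only in the configuration as drawn.

From the compounds shown here alone, the two stereocentres change together in this pair, so it remains open whether inverting either one alone would move the number in this assay, or whether the step is any larger than the usual scatter. Also open, going by these compounds, is what an amine or a carboxylic acid placed on the shared core would do to the tolerated concentration in this assay, in either configuration.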